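This account rests on a few compounds, and the source may have more. Where it says the series, first, only, none or still open, it means among the compounds named here.

Measured in an assay on HEK293 cells for agonist activity at transient receptor potential cation channel subfamily M member 8 (Homo sapiens), read by fluorescence and calcium flux, with a stated time of 15 min; on this read-out lower numbers stand for an effect already at smaller amounts and higher numbers for an effect only at larger amounts of compound:
compound 1 `C=CCN(Cc1cccs1)C(=O)COc1ccc(C)cc1`: 20 nM
compound 2 `Cc1ccc(OCC(=O)N(Cc2cccs2)c2c(C)n[nH]c2C)cc1`: 0.3 nM
compound 3 `Cc1ccc(OCC(=O)N(Cc2cccs2)c2cccnc2)cc1`: 198 nM

Compound 3 gives the highest number of the three in this assay; it is nearest to compound 1, furthest from compound 2. Compound 4 `Cc1ccc(OCC(=O)N(Cc2cccs2)c2nccn2C)cc1` differs from compound 3 in one place: 1-methyl-1H-imidazol-2-yl in place of pyridin-3-yl on an amide-type nitrogen. Both measured steps at this position bear on it: a 9.9-fold higher number from compound 1 to compound 3 (1.00 log units; beyond the scatter) and a 660-fold higher number from compound 2 to compound 3 (2.82 log units; beyond the scatter), so the group on the amide-type nitrogen moves the read-out strongly in this assay, and the only other five-membered aromatic ring with 2 hetero atoms there, in compound 2, gave the lowest number. Compound 4 is therefore expected to give a lower number than compound 3, with a 13-fold lower number from compound 3 to compound 4 (1.12 log units; beyond the scatter) as the estimated step. The estimate for compound 4 in this assay is 15 nM, within 1 nM to 200 nM.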

Compound 4, half-maximal effective concentration: 1790 nM
Compound 4: the middle estimate sits 120-fold (2.08 log units) below what was measured; measured number outside the range, above it.
By their numbers in this assay, from the lowest: compound 2; then compound 1; then compound 3; then compound 4.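

In this assay, a five-membered aromatic ring with 2 hetero atoms on the amide-type nitrogen does not by itself give a low number: 1-methyl-1H-imidazol-2-yl in place of 3,5-dimethyl-1H-pyrazol-4-yl gives a 6000-fold higher number from compound 2 to compound 4 (3.78 log units; beyond the scatter). The same group gives a 90-fold higher number from compound 1 to compound 4 (1.95 log units; beyond the scatter) against allyl and a 9.0-fold higher number from compound 3 to compound 4 (0.96 log units; beyond the scatter) against pyridin-3-yl, so ring size and hetero atom count alone do not order this position. Nothing available explains these steps. Open, going by these compounds, is whether the low number of compound 2 depends on its two methyl groups or on its ring hydrogen on nitrogen. Also open, on these data alone, is how phenyl or a saturated amine such as piperidinyl behaves on this nitrogen.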